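The source may hold more compounds than are shown below. What is called first, only, known or untested is meant among the compounds shown, and "the series" means these compounds.

In a physicochemical assay for lipophilicity, read by HPLC, at pH 7.5 (on this read-out lower numbers stand for lower lipophilicity and higher numbers for higher lipophilicity), compound 2 `CCOc1ccccc1-c1ccc(-c2nc3cnccc3c(N[C@H](CC)C(=O)NS(=O)(=O)C3CC3)c2C#N)cc1` gives 2.3 and compound 1 `CCOc1ccccc1-c1ccc(-c2nc3cnccc3c(NC(C)C(=O)O)c2C#N)cc1` gives 2.1, so the two stand level within the usual scatter. Compound 3 `CCOc1ccccc1-c1ccc(-c2nc3cnccc3c(N)c2C#N)cc1` differs from compound 2 at a single place, where the whole side group is removed: a hydrogen atom in place of a group of 12 heavy atoms (7 carbon, 1 nitrogen, 3 oxygen, 1 sulfur; one three-membered non-aromatic ring of carbon only), on a nitrogen on an aromatic ring. Among the compounds with values here, only one measured step bears on this change, a number 0.20 log units higher from compound 1 to compound 2 (within the scatter). That step exchanged one group on the same nitrogen for a larger one and left the number within the scatter. However, both measured compounds still carry a group there, and neither shows that nitrogen with only hydrogen on it. The step is therefore a weak guide to this larger change, and the expectation is uncertain. A clear rise is nevertheless expected, a number 1.40 log units higher from compound 2 to compound 3 (beyond the scatter). For compound 3 the estimated value is 3.7, with an expected range of 2.9 to 4.5.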

Compound 3, distribution coefficient: 3
Compound 3: middle estimate off by 0.70 log units, on the high side, within the range that was stated.
By their numbers in this assay, from the lowest: compounds 1 and 2 (each within the scatter of the next); then compound 3.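

Within the data shown here, with only hydrogen on the nitrogen on the aromatic ring, the number in this assay moves beyond the scatter for the first time in this set (a number 0.70 log units higher from compound 2 to compound 3 (beyond the scatter); a number 0.90 log units higher from compound 1 to compound 3 (beyond the scatter)). The two earlier compounds stood level although their groups differ in size, so they could not show that this position can affect the read-out at all; the comparison with hydrogen now shows that it can, with either group. No measurement shown accounts for the shift.

From the compounds shown here alone, what remains open is how much of the shift depends on the size of the group and how much on its atoms. A methyl group or a longer plain carbon chain on that nitrogen, or a methyl ester in place of the carboxylic acid, would help separate the two.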